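A single swap on a soluble compound

A few compounds are considered here, and "the series" means these few. Any claim that something is new, unique, unknown or untested is made for them only; others in the source may bear on it.

Compound 1 `Nc1cc(Oc2ccc3c(ccn3C(=O)Nc3cccc(C(F)(F)F)c3)c2)ncn1` reads < 5000 nM as a limit, not a number
Compound 2 `CCN1CCc2c(ncnc2Oc2ccc3c(ccn3C(=O)Nc3cccc(C(F)(F)F)c3)c2)C1` reads < 5000 nM as a limit, not a number
Compound 3 `Cc1cncc(NC(=O)n2ccc3cc(Oc4ncnc5c4CCNC5)ccc32)c1` reads 190000 nM as a measured number

All three compounds were tested in a physicochemical assay for solubility, at pH 6.8; on this read-out lower numbers stand for lower solubility and higher numbers for higher solubility. The results for compound 1 and compound 2 give no exact figure, and the record comes down to the limit of < 5000 nM in this assay, at which 2 of the 3 values shown sit, in those two cases. Among the compounds with values here, compound 3 therefore stands alone, and it holds the only true number on this scale, 190000 nM in all.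

Compound 4 `CC(C)c1cc(NC(=O)n2ccc3cc(Oc4ncnc5c4CCNC5)ccc32)n[nH]1` has not yet been measured. It keeps the shared core of compound 3 and changes one group on an amide-type nitrogen: 5-isopropyl-1H-pyrazol-3-yl in place of 5-methylpyridin-3-yl on an amide-type nitrogen. Here 5-isopropyl-1H-pyrazol-3-yl takes the place of 5-methylpyridin-3-yl.

Within the data shown here, no two measured compounds differ in one place, so no measured step guides this expectation. Compound 3 reads 190000 nM, and from there a fall looks likelier than a rise. The other two results are only limits. The expected change in this assay is a 2.7-fold lower number from compound 3 to compound 4 (0.43 log units; beyond the scatter), a moderate estimated drop that would lie beyond the usual scatter. For compound 4 the estimated value is 70000 nM, with an expected range from 15000 nM to 200000 nM.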

Compound 4, solubility: 833000 nM
For compound 4 the middle estimate is 12-fold (1.08 log units) below the measured one; the measured number lies above the stated range.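

In this assay, the group on the amide-type nitrogen can move the read-out clearly: putting 5-isopropyl-1H-pyrazol-3-yl in place of 5-methylpyridin-3-yl gives a 4.4-fold higher number from compound 3 to compound 4 (0.64 log units; beyond the scatter). This is the only pair shown that differs in one place, so this position now has a measured direction, and that direction is upward, with the five-membered aromatic ring carrying a hydrogen-bond donor going with the higher number. A single step changes the ring, the donor count and the alkyl group all at once, so it cannot separate them, and nothing measured here gives a reason for the rise.

Still open, going by these compounds, is which part of the swap carries the rise, a question that 5-methyl-1H-pyrazol-3-yl or 5-isopropylpyridin-3-yl on the same nitrogen could address, as could a version of the ring bearing a carboxylic acid or a primary amine. Compound 1 and compound 2 cannot help with this, as each differs from the others in more than one place and each reads only as a limit: the limit of < 5000 nM in this assay, at which 2 of the 4 values shown sit.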